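A few compounds are considered here, and "the series" means these few. Any claim that something is new, unique, unknown or untested is made for them only; others in the source may bear on it.

Compound 1, `COc1ccc2c(OCC[C@@H]3NC(=O)N(C)CCCC/C=C\[C@@H]4C[C@@]4(C(=O)NS(=O)(=O)C4CC4)NC3=O)cc(-c3nc(C(C)C)cs3)nc2c1Cl`, is the starting point of this account. In an ADME assay on cells (Homo sapiens) for activation (a lower number here means that less compound is tolerated, a higher number that more compound is tolerated), compound 1 gives 40400 nM. Two close relatives of compound 1 have been measured in the same way: compound 2, `COc1ccc2c(OCC[C@@H]3NC(=O)N(C)CCCC/C=C\[C@@H]4C[C@@]4(C(=O)NS(=O)(=O)N4CCC[C@H]4C#N)NC3=O)cc(-c3nc(C(C)C)cs3)nc2c1Cl`, gives 28300 nM, and compound 3, `COc1ccc2c(OCC[C@@H]3NC(=O)N(C)CCCC/C=C\[C@@H]4C[C@@]4(C(=O)NS(=O)(=O)C4(C)CC4)NC3=O)cc(-c3nc(C(C)C)cs3)nc2c1Cl`, gives 37400 nM. Neither relative is set apart from compound 1, since the step of a 1.4-fold lower number from compound 1 to compound 2 (0.15 log units; within the scatter) and the step of a 1.1-fold lower number from compound 1 to compound 3 (0.03 log units; within the scatter) both lie within the scatter, as does the step of a 1.3-fold higher number from compound 2 to compound 3 (0.12 log units; within the scatter) between the two relatives themselves.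

The compound that has not yet been measured is compound 4, `COc1ccc2c(OCC[C@@H]3NC(=O)N(C)CCCC/C=C\[C@@H]4C[C@@]4(C(=O)NS(=O)(=O)C4CC4)NC3=O)cc(-c3nc(C(C)C)cs3)nc2c1F`. It differs from compound 1 in one place: fluoro in place of chloro on an aromatic carbon. None of the three measured steps touches this part of the shared core; all of them alter the group on the sulfonyl sulfur, and each of them stayed within the scatter. Among the measured compounds shown here, there is therefore no measured step that speaks directly to the exchange of chloro for fluoro, and nothing in the three numbers hints at a change of any size beyond the scatter.

On that basis compound 4 is expected to sit close to compound 1, with an expected step of a 1.0-fold lower number from compound 1 to compound 4 (0.00 log units; within the scatter). The estimate for compound 4 in this assay is 40000 nM, with a range from 20000 nM to 80000 nM.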

Compound 4, half-maximal cytotoxic concentration: > 75000 nM
Compound 4: only a limit was reported; the forecaster's own chance of this, stated with the estimate: 10%; middle value at least 1.8-fold (0.27 log units) from the limit.
By their numbers in this assay, from the lowest: compounds 2, 3 and 1 (each within the scatter of the next). At a limit, above all of these: compound 4.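

The exchange of chloro for fluoro is the first change shown at this position, on an aromatic carbon ortho to a methoxy group, whereas all the earlier steps altered the group on the sulfonyl sulfur. In this assay compound 4 gives > 75000 nM as a limit of the assay. The step reads an at least 1.8-fold higher number from compound 1 to compound 4 (0.26 log units; that floor lies within the scatter) and so gives a floor rather than a size: this exchange brings no lower number, but no rise beyond the scatter is established, and how far the true value lies past that floor cannot be read, the reading being capped by this: the limit of > 75000 nM in this assay, at which 1 of the 4 values shown sits.

The compounds shown leave open how a bromo group, a methyl group or a plain hydrogen on this aromatic carbon would read in this assay, and so whether chloro and fluoro are typical of what this position allows. They also leave open whether fluoro on this carbon would read the same alongside the 2-cyanopyrrolidin-1-yl or 1-methylcyclopropyl group on the sulfonyl sulfur.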